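Swapping the alkyne end for a methyl on the amine

The compounds below may be only part of what the source reports. "The series", "measured", "known", "first", "only" and "open" are said of these compounds alone.

Measured compounds:
- Compound 1, `C#CCN(CCCCCCN1C(=O)c2ccccc2C1=O)Cc1ccccc1`: 8200 nM
- Compound 2, `C#CCN(CCCCCCN1C(=O)c2ccccc2C1=O)Cc1ccccc1OC`: 9100 nM
- Compound 3, `CC(C)N1CCN(CCCCN2C(=O)c3ccccc3C2=O)CC1`: 8900 nM

In an assay on cells for inhibition of Amine oxidase [flavin-containing] B (Homo sapiens), read by fluorescence, with a stated time of 30 min (a lower number here means a stronger inhibitor, a higher number a weaker inhibitor), compound 2 gives the highest of the three numbers, though all three sit within the scatter of one another: compound 3 and compound 1 lie closest and furthest, and neither gap exceeds the scatter, so no order among them can be claimed. For the measured compounds named here, the one step that connects two measured compounds, a 1.1-fold higher number from compound 1 to compound 2 (0.05 log units; within the scatter), is also within the scatter.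

Compound 4, `CCN(CCCCCCN1C(=O)c2ccccc2C1=O)Cc1ccccc1OC`, differs from compound 2 by methyl in place of ethynyl on a saturated chain carbon bound to an amine nitrogen. Going by the values given here, no measured step touches this part of the molecule: the only step on record concerns the methoxy on the aromatic ring, not the group on the amine nitrogen. The expectation for compound 4 therefore rests mainly on the value of compound 2, 9100 nM, with a wide band of uncertainty, and no direction can be predicted with confidence. The estimated step from compound 2 to compound 4 is a 1.6-fold higher number from compound 2 to compound 4 (0.22 log units; within the scatter). Compound 4 is expected to give about 15000 nM, within a range from 5000 nM to 60000 nM.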

Compound 4, half-maximal inhibitory concentration: 11700 nM
Estimate against measurement, compound 4: 1.3-fold (0.11 log units) above; low and high end bracket the measured number.
By their numbers in this assay, from the lowest: compounds 1, 3, 2 and 4 (each within the scatter of the next).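

For the compounds shown here, this is the first step on record at the group on the amine nitrogen: replacing propargyl with ethyl in this assay gives a 1.3-fold higher number from compound 2 to compound 4 (0.11 log units; within the scatter). For this one pair, then, the swap gives no step beyond the scatter, so the triple bond is not shown to matter for the number here. Nothing measured alongside this result speaks to why the two compounds read so alike.

On these data alone, how a propyl chain or a cyclopropyl group would read at this position remains open. So does whether the same swap would give a similar step on compound 1, which carries hydrogen in place of the methoxy.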